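The compounds below may be only part of what the source reports. "The series", "measured", "known", "first", "only" and "open" are said of these compounds alone.

The measured compounds:

Compound 1 `Cc1ccc(NC(=O)NC(=O)c2ccc(OCc3cccc(Cl)c3)cc2)cc1-c1nc2ccccc2[nH]1`: 28000 nM
Compound 2 `Cc1ccc(NC(=O)NC(=O)c2ccc(OCc3ccc(C(F)(F)F)cc3)cc2)cc1-c1nc2ccccc2[nH]1`: 16800 nM
Compound 3 `Cc1ccc(NC(=O)NC(=O)c2ccc(OCc3cccc(C(F)(F)F)c3)cc2)cc1-c1nc2ccccc2[nH]1`: 9600 nM

All three were tested in a functional assay on MNK45 cells (Homo sapiens) for inhibition, read by MTT assay, with a stated time of 48 h; on this read-out higher numbers stand for weaker inhibition and lower numbers for stronger inhibition. Among them compound 3 gives the lowest number; its gap to compound 2 is within the scatter, while the step of a 2.9-fold lower number from compound 1 to compound 3 (0.46 log units; beyond the scatter) lies beyond it. The steps of a 1.7-fold lower number from compound 1 to compound 2 (0.22 log units; within the scatter) and a 1.8-fold lower number from compound 2 to compound 3 (0.24 log units; within the scatter) are both within the scatter.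

Compound 4 `Cc1ccc(NC(=O)NC(=O)c2ccc(OCc3cccc(Cl)c3Cl)cc2)cc1-c1nc2ccccc2[nH]1` has not yet been measured in this assay. It differs from compound 3 in one place: 2,3-dichlorophenyl in place of 3-(trifluoromethyl)phenyl on a saturated chain carbon bound to an oxygen on an aromatic ring. For the measured compounds named here, the step that bears on this is a 2.9-fold lower number from compound 1 to compound 3 (0.46 log units; beyond the scatter), since compound 1 carries the chloro on the same ring and compound 4 returns to chloro there; the added second chloro has no counterpart among the measured compounds. The expected step of a 2.1-fold higher number from compound 3 to compound 4 (0.32 log units; beyond the scatter) therefore runs in the direction of a higher number, with about the size of the step from compound 1 to compound 3, though the second chloro leaves this uncertain. For compound 4 in this assay the estimate is 20000 nM, with a range from 7000 nM to 50000 nM.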

Compound 4, half-maximal inhibitory concentration: 87000 nM
Compound 4: middle estimate off by 4.4-fold (0.64 log units), on the low side, and the stated range ends below it.
By their numbers in this assay, from the lowest: compounds 3, 2 and 1 (each within the scatter of the next, the first and the last beyond it); then compound 4.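

In this assay, a second chloro on the ring gives a 3.1-fold higher number from compound 1 to compound 4 (0.49 log units; beyond the scatter), so adding to this ring can raise the number and not only shift it slightly, as the earlier exchanges did. Set against the trifluoromethyl compounds, the 2,3-dichlorophenyl group gives a 9.1-fold higher number from compound 3 to compound 4 (0.96 log units; beyond the scatter) and a 5.2-fold higher number from compound 2 to compound 4 (0.71 log units; beyond the scatter); compound 4 is thus the weakest of the four, and this place on the saturated chain carbon spans a wider range of numbers than the first three compounds showed. No measurement is available that would account for this rise.

The compounds shown leave open how a phenyl without any chloro or trifluoromethyl would compare. They also leave open whether a nitrile, a methoxy group or an amine on this ring would give a lower or a higher number.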